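The compounds below may be only part of what the source reports. "The series", "measured", "known", "first", "only" and "open" are said of these compounds alone.

Of the compounds shown here, two have been measured so far in a functional assay on HeLa cells (Homo sapiens) for antiproliferative activity, read by MTT assay, with a stated time of 48 h; on this read-out lower numbers stand for stronger inhibition and higher numbers for weaker inhibition. Compound 1 `Cc1cc2nc(-c3cn(-c4ccccc4)nc3-c3ccccc3)[nH]c2cc1C` gives 41500 nM, and compound 2 `Cc1ccc2[nH]c(-c3cn(-c4ccccc4)nc3-c3ccc(F)cc3)nc2c1` gives 3630 nM. Compound 2 therefore holds the lower of the two numbers, and the gap between them lies beyond the scatter. These two compounds differ in more than one place, so their values do not isolate any single change.

Compound 3 `Cc1cc2nc(-c3cn(-c4ccccc4)nc3-c3ccc(F)cc3)[nH]c2cc1C` departs from compound 2 in one place: methyl in place of hydrogen on an aromatic carbon, with methyl in place of hydrogen on an aromatic carbon. Among the measured compounds shown here, no measured pair shows this change alone, so the expectation in this assay is tentative: a modest move towards weaker inhibition, which may not exceed the scatter. Compound 3 shares the entering methyl with compound 1, and compound 1 stands at 41500 nM, which tilts the expectation upwards. The estimated step is a 1.7-fold higher number from compound 2 to compound 3 (0.22 log units; within the scatter). For compound 3 the expected value is 6000 nM, with an estimated range of 2000 nM to 20000 nM.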

Compound 3, half-maximal inhibitory concentration: 10200 nM
The estimate for compound 3 lay 1.7-fold (0.23 log units) below the measured number; low and high end bracket the measured number.
By their numbers in this assay, from the lowest: compound 2; then compound 3; then compound 1.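

In this assay, among the compounds shown here, the second methyl, placed on an aromatic carbon of the six-membered aromatic ring of carbon only and ortho to a methyl group, gives a 2.8-fold higher number from compound 2 to compound 3 (0.45 log units; beyond the scatter) as the first reading of this change on its own, and it lies beyond the scatter. The other single change can now be read as well: the added fluoro gives a 4.1-fold lower number from compound 1 to compound 3 (0.61 log units; beyond the scatter) with the two methyl groups held constant, and this step also lies beyond the scatter. The two changes therefore run in opposite directions on this read-out, with the added methyl moving towards weaker inhibition and the added fluoro towards stronger inhibition, although each direction rests on a single pair of compounds.

Nothing available here bears on the reason for either step. The compounds shown leave open whether the move towards weaker inhibition is particular to methyl or also appears with an ethyl, a methoxy or an amine at this position, and whether a chloro in place of the fluoro would give a step of similar size.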